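Compound 3 to compound 4: branching the pentyl chain

The source may report more compounds than this note shows. Statements on the series, on what has been measured and on what is new or still open speak of the compounds shown alone.

Compound 1 `C=C1C(=O)O[C@H]2CC3=C[C@H](C/C(C)=C/[C@@H](OC(=O)c4ccc(C(C)=O)cc4)[C@H]12)OC3=O` gives 2300 nM in a functional assay on A549 cells (Homo sapiens) for cytotoxicity, read by MTT assay, with a stated time of 48 h (on this read-out lower numbers stand for stronger inhibition and higher numbers for weaker inhibition), on the shared core. Compound 2 `C=C1C(=O)O[C@H]2CC3=C[C@H](C/C(C)=C/[C@@H](OC(=O)/C=C/c4ccccc4)[C@H]12)OC3=O` gives 4800 nM in this assay on the same core. Compound 3 `C=C1C(=O)O[C@H]2CC3=C[C@H](C/C(C)=C/[C@@H](OC(=O)CCCCC)[C@H]12)OC3=O` stands at > 10000 nM in this assay and this is a limit of the assay, not a number.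

Compound 4 `C=C1C(=O)O[C@H]2CC3=C[C@H](C/C(C)=C/[C@@H](OC(=O)CC(C)C)[C@H]12)OC3=O` is still unmeasured. Its change from compound 3 is isopropyl in place of butyl on a saturated chain carbon bound to a carbonyl carbon and amounts to pentyl going to isobutyl, with no ring entering.

The nearest evidence is an at least 4.3-fold higher number from compound 1 to compound 3 (0.63 log units; beyond the scatter) with pentyl in place of 4-acetylphenyl, and an at least 2.0-fold higher number from compound 2 to compound 3 (0.31 log units; beyond the scatter) with pentyl in place of 2-phenylethenyl. The remaining step is a 2.1-fold higher number from compound 1 to compound 2 (0.32 log units; beyond the scatter) with 2-phenylethenyl in place of 4-acetylphenyl. All three exchange a group carrying a ring or a double bond, and none swaps one saturated chain for another, so none sizes this change directly.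

The expectation therefore rests on compound 3 with its limit of > 10000 nM as the only saturated chain measured so far. The expected step is an at least 1.1-fold lower number from compound 3 to compound 4 (0.04 log units; that floor lies within the scatter) and no shift beyond the scatter is anticipated in this assay for now. Compound 4 is estimated at 9000 nM with an expected range from 4000 nM to 20000 nM and may well read only as a limit.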

Compound 4, half-maximal inhibitory concentration: 2500 nM
Beside the measured number, compound 4's estimate is 3.6-fold (0.56 log units) above it; the whole stated range lies above it.
By their numbers in this assay, from the lowest: compounds 1, 4 and 2 (each within the scatter of the next, the first and the last beyond it). At a limit, above all of these: compound 3.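

In this assay, saturated chains on this carbonyl carbon do not all read alike: isopropyl in place of butyl on a saturated chain carbon bound to a carbonyl carbon gives an at least 4.0-fold lower number from compound 3 to compound 4 (0.60 log units; beyond the scatter), a shift from pentyl to isobutyl with no ring entering. Compound 3 carries a limit of the assay and not a number, which makes that step a floor only: the limit of > 10000 nM in this assay, at which 1 of the 4 values shown sits. A ring or a double bond in the acyl group is also not required for a reading in this range, as isobutyl in place of 2-phenylethenyl gives a 1.9-fold lower number from compound 2 to compound 4 (0.28 log units; within the scatter) and isobutyl in place of 4-acetylphenyl gives a 1.1-fold higher number from compound 1 to compound 4 (0.04 log units; within the scatter), which leaves compound 4 indistinguishable from compound 2 and from compound 1 here.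

Pentyl and isobutyl differ both in chain length and in branching, so the compounds shown cannot separate the two, and a straight butyl chain on the carbonyl carbon would address that directly. Also open, from the compounds shown here alone, is how far the isobutyl result extends to other saturated groups, such as tert-butyl or cyclohexyl, or to a chain bearing an amine.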